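Adding one fluoro to compound 3

The compounds below may be only part of what the source reports. "The series", "measured", "known", "first", "only" and "open" are said of these compounds alone.

In a functional assay on MCF7 cells (Homo sapiens) for cytotoxicity, read by MTT assay, with a stated time of 72 h (on this read-out higher numbers stand for weaker inhibition and lower numbers for stronger inhibition), compound 1 `Cn1ccc2c(Oc3ccc(NC(=O)c4cc5cccnc5n(-c5ccccc5)c4=O)cc3)ncnc21` gives 88400 nM and compound 2 `Cn1ccc2c(Oc3ccc(NC(=O)c4cc5cccnc5n(-c5ccc(Br)cc5)c4=O)cc3)ncnc21` gives 79400 nM while compound 3 `Cn1ccc2c(Oc3ccc(NC(=O)c4cc5cccnc5n(-c5ccccc5)c4=O)cc3F)ncnc21` gives 73400 nM and so stands within the scatter of both others. All three values sit close together, and none of the three can be singled out on these numbers.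

Compound 4 `Cn1ccc2c(Oc3ccc(NC(=O)c4cc5cccnc5n(-c5ccc(F)cc5)c4=O)cc3F)ncnc21` departs from compound 3 at a single place. The change is fluoro in place of hydrogen on an aromatic carbon and in words it is fluoro in place of hydrogen on an aromatic carbon, para to a large group, which turns phenyl to 4-fluorophenyl.

Within the data shown here, two measured steps bear on this change. Bromo in place of hydrogen on the phenyl gave a 1.1-fold lower number from compound 1 to compound 2 (0.05 log units; within the scatter) and fluoro in place of hydrogen elsewhere in the molecule gave a 1.2-fold lower number from compound 1 to compound 3 (0.08 log units; within the scatter) and both are small. Neither step shows fluoro at this exact place, so the evidence is indirect. Even so, with those two steps inside the scatter, no step beyond the scatter is expected in this assay here. The estimated step is a 1.0-fold lower number from compound 3 to compound 4 (0.02 log units; within the scatter) and no direction can be claimed for it with confidence. For compound 4 the expected value is 70000 nM with an estimated range from 40000 nM to 115000 nM in this read-out.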

Compound 4, half-maximal inhibitory concentration: 11900 nM
For compound 4 the middle estimate is 5.9-fold (0.77 log units) above the measured one, outside the stated range (below it).
By their numbers in this assay, from the lowest: compound 4; then compounds 3, 2 and 1 (each within the scatter of the next).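

In this assay the change from phenyl to 4-fluorophenyl gives a 6.2-fold lower number from compound 3 to compound 4 (0.79 log units; beyond the scatter), the only step shown here that lies beyond the scatter, so this position can matter in this assay even though the earlier compounds gave no sign of it. Bromo in place of hydrogen on the same phenyl gave a 1.1-fold lower number from compound 1 to compound 2 (0.05 log units; within the scatter), within the scatter, but that step started from a compound without the fluoro that compound 3 carries elsewhere in the molecule, so the two steps differ both in the entering group and in the starting compound. Nothing shown here offers a measured explanation for the step to compound 4.

The compounds shown leave open whether the 4-fluorophenyl change would give a similar step without that other fluoro, which would tell whether the effect belongs to this fluoro alone or to the two fluoro groups together. They also leave open whether chloro, methoxy or an amine at this place would behave like fluoro or like bromo.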